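The source may report more compounds than this note shows. Statements on the series, on what has been measured and on what is new or still open speak of the compounds shown alone.

Three compounds have numbers in a physicochemical assay for lipophilicity, using the shake flask method, measured as octanol-water partition; on this read-out higher numbers stand for higher lipophilicity and lower numbers for lower lipophilicity. Compound 1 (`CCCCCCCCCC(=O)NNC(=O)c1ccncc1`) gives 3.46, compound 2 (`O=C(NN=C1CCC(c2ccccc2)CC1)c1ccncc1`) gives 1.97, and compound 3 (`O=C(N/N=C/c1cccc(CO)c1)c1ccncc1`) gives 0.902. Compound 3 therefore stands lowest of the three, and both of the others lie higher by margins beyond the scatter of repeated measurements.

Compound 4 (`O=Cc1cccc(/C=N/NC(=O)c2ccncc2)c1`) has not yet been measured in this assay. It departs from compound 3 in one place: formyl in place of hydroxymethyl on an aromatic carbon, which amounts to formyl in place of hydroxymethyl on an aromatic carbon. Within the data shown here, no two measured compounds differ in one place only, so the numbers offer no direct guide to this change. A modest rise in this assay is nevertheless expected, probably just beyond the scatter, although a result within the scatter remains possible. The expected move is a number 0.40 log units higher from compound 3 to compound 4 (beyond the scatter). This expectation takes as its starting point compound 3 at 0.902. For compound 4 the estimated value is 1.3, with an expected range from 0.9 to 1.7.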

Compound 4, partition coefficient: 1.33
Compound 4: the middle estimate sits 0.03 log units below what was measured, within the range that was stated.
By their numbers in this assay, from the lowest: compound 3; then compound 4; then compound 2; then compound 1.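

In this assay, among these compounds, formyl in place of hydroxymethyl on an aromatic carbon, meta to a large group, gives the first step that can be read at a single place: a number 0.43 log units higher from compound 3 to compound 4 (beyond the scatter) on the shared core. The two groups match in heavy atoms, one carbon and one oxygen each, and each carries one hydrogen-bond acceptor; the entering formyl brings one double bond outside aromatic rings and no hydrogen-bond donor, so a step beyond the scatter can occur here with no change in heavy-atom count. No measurement shown here bears on what lies behind this step.

This single pair leaves open whether the same change gives a similar step on a different core. It also leaves open where a carboxylic acid, an amine or a nitrile on this aromatic carbon would stand in this assay relative to hydroxymethyl and formyl.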